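Ethoxycarbonyl in place of (tert-butoxycarbonyl)amino

The source may hold more compounds than are shown below. What is called first, only, known or untested is meant among the compounds shown, and "the series" means these compounds.

Going by the values given here, in a functional assay on HCT-116 cells (Homo sapiens) for antiproliferative activity, read by MTT assay, with a stated time of 72 h (a lower number here means a stronger inhibitor, a higher number a weaker inhibitor), compound 2 `CC(C)(C)OC(=O)Nc1ccc(NC(=O)CCc2cccc3c2B(O)OC3)cc1` gives 24000 nM, the higher of the two numbers measured so far. Compound 1 `O=C(CCc1cccc2c1B(O)OC2)Nc1ccc(F)cc1`, which carries fluoro in place of (tert-butoxycarbonyl)amino, gives 650 nM. Compound 3 `CCOC(=O)c1ccc(NC(=O)CCc2cccc3c2B(O)OC3)cc1` has ethoxycarbonyl in place of (tert-butoxycarbonyl)amino on an aromatic carbon. Among the compounds with values here, the only measured step that bears on this change is a 37-fold higher number from compound 1 to compound 2 (1.57 log units; beyond the scatter), a large step that came with the arrival of the group now leaving. Within the data shown here, a move towards a lower number is therefore expected, but no measured compound carries ethoxycarbonyl, so a full return to the level of compound 1 is not assumed. The expected change is an 8.0-fold lower number from compound 2 to compound 3 (0.90 log units; beyond the scatter). In this assay, the estimate for compound 3 is 3000 nM, with the measurement expected to fall between 600 nM and 15000 nM.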

Compound 3, half-maximal inhibitory concentration: > 100000 nM
Compound 3 was reported as a limit; the forecaster's own chance of this, stated with the estimate: 5%; middle value at least 33-fold (1.52 log units) away from the limit.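

The reading for compound 3 in this assay is a limit and not a number: the limit of > 100000 nM in this assay, at which 1 of the 3 values shown sits. Even so, it shows that removing (tert-butoxycarbonyl)amino from this aromatic carbon does not by itself lower the number. Putting ethoxycarbonyl there gives an at least 4.1-fold higher number from compound 2 to compound 3 (0.61 log units; beyond the scatter), and the change from fluoro gives an at least 150-fold higher number from compound 1 to compound 3 (2.18 log units; beyond the scatter). Heavy-atom count alone therefore does not order these two groups, since ethoxycarbonyl has fewer heavy atoms than (tert-butoxycarbonyl)amino yet compound 3 stands on the higher side of compound 2.

From the compounds shown here alone, whether an amine or a carboxylic acid at this place would bring the number back towards compound 1 at 650 nM remains open. Also open, going by these compounds, is how far the true value of compound 3 lies past its limit.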